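The compounds below may be only part of what the source reports. "The series", "measured", "known", "first", "only" and "open" are said of these compounds alone.

In a functional assay on SW-620 cells (Homo sapiens) for cytotoxicity, read by MTT assay, with a stated time of 72 h (a lower number here means a stronger inhibitor, a higher number a weaker inhibitor), compound 1 `COc1cccc(/C=C2\CCC/C(=C\c3cccc(Cl)c3)C2=O)c1OC` gives 9100 nM and compound 2 `COc1ccc(/C=C2\CCC/C(=C\c3cccc(OC)c3OC)C2=O)cc1` gives 13600 nM, with a 1.5-fold higher number from compound 1 to compound 2 (0.17 log units; within the scatter). Compound 3 `COc1cccc(/C=C2\CCC/C(=C\c3ccc(O)cc3)C2=O)c1OC` reports only > 20000 nM, which is a limit of the assay and not a number. Compound 3 therefore stands at the limit of > 20000 nM in this assay, at which 1 of the 3 values shown sits.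

The next structure, compound 4 `COc1cccc(/C=C2\CCC/C(=C\c3cccc(Cl)c3Cl)C2=O)c1OC`, carries 2,3-dichlorophenyl in place of 4-hydroxyphenyl on a double-bonded chain carbon bound to a double-bonded ring carbon. The closest measured change is an at least 2.1-fold higher number from compound 1 to compound 3 (0.34 log units; beyond the scatter), with 4-hydroxyphenyl in place of 3-chlorophenyl at that same place. Read in reverse, it points to a lower number when a chlorinated phenyl replaces 4-hydroxyphenyl. The other step into compound 3, an at least 1.4-fold higher number from compound 2 to compound 3 (0.16 log units; that floor lies within the scatter), adds little, since its floor lies within the scatter.

A modest move toward a lower number in this assay is thus expected, leaving the new compound near compound 1 at 9100 nM. The expected change is an at least 2.5-fold lower number from compound 3 to compound 4 (0.39 log units; beyond the scatter). The estimate for compound 4 is 8000 nM, with an expected range of 3500 nM to 18000 nM.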

Compound 4, half-maximal inhibitory concentration: 16300 nM
Compound 4: middle estimate off by 2.0-fold (0.31 log units), on the low side, within the range that was stated.
By their numbers in this assay, from the lowest: compounds 1, 2 and 4 (each within the scatter of the next). At a limit, above all of these: compound 3.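

Compound 4 shows that 2,3-dichlorophenyl at this place on a double-bonded chain carbon bound to a double-bonded ring carbon cannot be told apart from the groups in the other two numbered compounds in this assay: the readings are a 1.8-fold higher number from compound 1 to compound 4 (0.25 log units; within the scatter) for chloro in place of hydrogen on an aromatic carbon and a 1.2-fold higher number from compound 2 to compound 4 (0.08 log units; within the scatter) for 2,3-dichlorophenyl in place of 4-methoxyphenyl. Neither a second chloro nor this exchange therefore gives a change beyond the scatter. The reading an at least 1.2-fold lower number from compound 3 to compound 4 (0.08 log units; that floor lies within the scatter) gives no true size for the step, because the value of compound 3 is a limit of the assay and not a number: the limit of > 20000 nM in this assay, at which 1 of the 4 values shown sits.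

Going by these compounds, the true value of compound 3 stays open, and so does any group at this place that would separate from compounds 1, 2 and 4. An amine or a carboxylic acid on that phenyl ring is one such open case.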